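Three Sulfamate Amides and an Untested Fourth

A few compounds are considered here, and "the series" means these few. Any claim that something is new, unique, unknown or untested is made for them only; others in the source may bear on it.

Of the compounds shown here, three sharing one core have been measured in an assay on HEK293 cells for inhibition of Steryl-sulfatase (Homo sapiens), tested at 0.1 uM; on this read-out higher numbers stand for a stronger effect at the one concentration tested and lower numbers for a weaker effect. Compound 1 `NS(=O)(=O)Oc1ccc2c(c1)CN(C(=O)c1cccc(N3CCC(Cc4ccccc4)CC3)c1)CC2` gives 1.4% in this assay. Compound 2 `CN(C)CCN(CCN(C)C)c1ccc(C(=O)N2CCc3ccc(OS(N)(=O)=O)cc3C2)cc1` gives 3.8% in this assay, and compound 3 `NS(=O)(=O)Oc1ccc2c(c1)CN(C(=O)c1ccc(N3CCC(N4CCCCC4)CC3)cc1)CC2` gives 8.5%. Compound 2 has the second highest of the three numbers; its nearest neighbour is compound 1, whose number lies within the scatter of it, and the furthest is compound 3, whose number also lies within the scatter. Among the measured compounds shown here, no pair of these three differs in only one place, so no single step between measured compounds can be read off.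

Compound 4 `CCCN(Cc1ccccc1)c1ccc(C(=O)N2CCc3ccc(OS(N)(=O)=O)cc3C2)cc1` has not yet been measured. It differs from compound 2 in one place: benzyl(propyl)amino in place of bis(2-(dimethylamino)ethyl)amino on an aromatic carbon The leaving group and the entering group are counted at the same number of heavy atoms, and the place is on an aromatic carbon of a six-membered aromatic ring of carbon only, para to a large group.

All three measured numbers sit within the scatter of one another, so nothing in the data points to a step beyond the scatter. The account therefore expects the step of a number 1.2 percentage points higher from compound 2 to compound 4 (within the scatter) to stay within the scatter, in no particular direction. Compound 4 is estimated at 5%, with a range from -5% to 18%.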

Compound 4, a percentage reported as inhibition, at one concentration (the size of the read-out at that concentration, not a potency): 64.8%
Beside the measured number, compound 4's estimate is 59.8 percentage points below it; measured number outside the range, above it.
By their numbers in this assay, from the lowest: compounds 1, 2 and 3 (each within the scatter of the next); then compound 4.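

In this assay, among the compounds shown here, the exchange of bis(2-(dimethylamino)ethyl)amino for benzyl(propyl)amino on this aromatic carbon, para to a large group, comes with a number 61 percentage points higher from compound 2 to compound 4 (beyond the scatter), so a single change at this place can move the read-out beyond the scatter, something the earlier compounds could not show. The two groups are counted at the same number of heavy atoms, so that count does not separate them; they differ in that the entering group carries one six-membered aromatic ring of carbon only and 1 nitrogen, while the leaving group has no ring and 3 nitrogens. No measurement at hand bears on why the step is this large.

On these data alone, whether the step follows the benzyl group, the propyl chain or the loss of the two 2-(dimethylamino)ethyl arms remains open, as all of these change together in this one exchange. Also open, as far as these compounds go, is how a dipropylamino or a benzyl(methyl)amino group would read at this place, either of which would keep only one part of the entering group.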